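A few compounds are considered here, and "the series" means these few. Any claim that something is new, unique, unknown or untested is made for them only; others in the source may bear on it.

In an ADME assay on liver (Homo sapiens) for metabolic stability, using microsomes (a higher number here means that the compound lasts longer, a lower number that the compound disappears faster), compound 1 `CN1Cc2cc(ccc2S(=O)(=O)C2CC2)NC(=O)CCc2cc(ccc2OCC2CC2)[C@@H](Nc2ccc3c(N)ncc(F)c3c2)C1=O` gives 0.383 h, compound 2 `COc1ccc2cc1CCC(=O)Nc1ccc(S(=O)(=O)C3CC3)c(c1)CN(C)C(=O)[C@@H]2Nc1ccc2c(N)ncc(F)c2c1` gives 0.233 h and compound 3 `CN1Cc2cc(ccc2S(=O)(=O)C2CC2)NC(=O)CCc2cc(ccc2C2CC2)[C@@H](Nc2ccc3c(N)ncc(F)c3c2)C1=O` gives 0.433 h. Compound 3 therefore cannot be separated from the other two, as every step among these compounds lies within the scatter. The next compound is compound 4 `CN1Cc2cc(ccc2S(=O)(=O)C2CC2)NC(=O)CCc2cc(ccc2OCC(F)F)[C@@H](Nc2ccc3c(N)ncc(F)c3c2)C1=O`, with 2,2-difluoroethoxy in place of cyclopropyl on an aromatic carbon. For the measured compounds named here, two steps bear on this most directly, a 1.1-fold higher number from compound 1 to compound 3 (0.05 log units; within the scatter) with cyclopropyl replacing cyclopropylmethoxy and a 1.9-fold higher number from compound 2 to compound 3 (0.27 log units; within the scatter) with cyclopropyl replacing methoxy. The change to compound 4 runs the other way, from cyclopropyl back to an oxygen-linked group. The step of a 1.6-fold lower number from compound 1 to compound 2 (0.22 log units; within the scatter) also shows the two oxygen-linked groups within the scatter of each other. No fluorinated group has been measured in this series, so that part of the change remains uncovered. No step beyond the scatter is expected in this assay, in either direction. The expected step is a 1.3-fold lower number from compound 3 to compound 4 (0.12 log units; within the scatter). The estimated half-life of compound 4 is 0.33 h, with an expected range of 0.17 h to 0.62 h.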

Compound 4, half-life: 0.533 h
Compound 4: the middle estimate sits 1.6-fold (0.21 log units) below what was measured; the range from low to high includes it.
By their numbers in this assay, from the lowest: compounds 2, 1, 3 and 4 (each within the scatter of the next, the first and the last beyond it).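

At this position, on an aromatic carbon, 2,2-difluoroethoxy brings the first fluorinated group into the series, and in this assay it cannot be separated from cyclopropyl, with a 1.2-fold higher number from compound 3 to compound 4 (0.09 log units; within the scatter), or from cyclopropylmethoxy, with a 1.4-fold higher number from compound 1 to compound 4 (0.14 log units; within the scatter). Against methoxy it gives the only step beyond the scatter among these compounds, a 2.3-fold higher number from compound 2 to compound 4 (0.36 log units; beyond the scatter), while compound 1 and compound 3 remain within the scatter of both ends. Nothing available explains this step.

What the fluorine atoms contribute stays open, as the compounds shown include no ethoxy group at this position. Also open, as far as these compounds go, is whether 2,2,2-trifluoroethoxy or an amine on this aromatic carbon would move the half-life beyond the scatter from compound 3.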